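The source may report more compounds than this note shows. Statements on the series, on what has been measured and on what is new or still open speak of the compounds shown alone.

Within the data shown here, compound 2 `COc1cc(OC)c(NC(=O)Cc2cn(C)c3ccccc23)cc1Cl` gives 4050 mL/min/kg in an ADME assay on microsomes from liver (Mus musculus) for metabolic stability (a lower number here means slower removal, a higher number faster removal of the compound), the only plain number among the three values recorded here. Compound 1 `C[C@@H](C(=O)O)c1nn(Cc2cn3cc(OCC4CC4)c(Cl)cc3n2)c2ccccc2c1=O` is reported only as a limit of this assay, < 55 mL/min/kg. Compound 3 `O=C(O)C1(c2nn(Cc3cn4cc(OCC5CC5)c(Cl)cc4n3)c3ccccc3c2=O)CC1` likewise gives only a limit, < 53.4 mL/min/kg. The step that the two limits leave unreadable from compound 1 to compound 3 cannot be sized because its ends sit at the limit of < 55 mL/min/kg in this assay, at which 1 of the 3 values shown sits, and at the limit of < 53.4 mL/min/kg in this assay, at which 1 of the 3 values shown sits. Compound 4 `COc1cc(OC)c(NC(=O)Cc2cn(CC(=O)O)c3ccccc23)cc1Cl` differs from compound 2 by carboxy in place of hydrogen on a saturated chain carbon bound to an aromatic nitrogen. Among the measured compounds shown here, no measured step covers this change, and the one recorded step has no readable size, so the data give no direction or size to expect for compound 4 in this assay. The estimate for compound 4 is 1500 mL/min/kg, with a range from 300 mL/min/kg to 4500 mL/min/kg. That corresponds to an expected step of a 2.7-fold lower number from compound 2 to compound 4 (0.43 log units; beyond the scatter).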

Compound 4, clearance: < 60 mL/min/kg
Compound 4 ended at the assay's limit; the forecaster's own chance of this, stated with the estimate: 10%; at least 25-fold (1.39 log units) between middle value and limit.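

In this assay, carboxy in place of hydrogen on a saturated chain carbon bound to an aromatic nitrogen gives an at least 67-fold lower number from compound 2 to compound 4 (1.82 log units; beyond the scatter). Among these compounds, the earlier step could not be read, so this is the first change with a size, and it shows that this position can carry a large difference. Compound 4 gives only a limit, < 60 mL/min/kg, so the step has a smallest size and no exact one. As far as these compounds go, it stays open whether an amine or a primary amide at this place would give a step of similar size. A longer chain ending in carboxy is equally untested here.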